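Aryl Swap on the Shared Core: Expected Growth Inhibition

The source may hold more compounds than are shown below. What is called first, only, known or untested is meant among the compounds shown, and "the series" means these compounds.

Measured compounds:
Compound 1, `Cc1ccc(-c2nn(-c3ccc(Br)cc3)c(/N=C/N(C)C)c2C=O)cc1`: 6700 nM
Compound 2, `Cc1ccc(-c2cc(/N=C/N(C)C)n(-c3cccc(Cl)c3)n2)cc1`: > 100000 nM

In a functional assay on Jurkat cells (Homo sapiens) for inhibition, read by MTT assay, with a stated time of 72 h (on this read-out higher numbers stand for weaker inhibition of growth and lower numbers for stronger inhibition of growth), compound 1 gives 6700 nM. Compound 2 gives > 100000 nM, which is a limit of this assay and not a number. Compound 2 thus stands at the limit of > 100000 nM in this assay, at which 1 of the 2 values shown sits, so only a lower bound on its growth-inhibiting concentration is known, and its true value may lie anywhere beyond it.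

Compound 3, `Cc1ccc(-c2cc(/N=C/N(C)C)n(-c3ccc(Br)cc3)n2)cc1`, differs from compound 2 in one place: 4-bromophenyl in place of 3-chlorophenyl on an aromatic nitrogen. Among the measured compounds shown here, no measured pair shows the effect of this change, so the step from compound 2 to compound 3 is expected to be small, with no direction beyond the usual scatter. Compound 3 is therefore estimated at 120000 nM, within a range of 30000 nM to 500000 nM, and the expected step is a step that the limit leaves unreadable from compound 2 to compound 3.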

Compound 3, concentration for 50% growth inhibition: > 100000 nM
Compound 3 ended at the assay's limit; the forecaster's own chance of this, stated with the estimate: 65%; the middle value is on the limit's open side.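

Among the compounds shown here, the first readable pair that differs in one place shows that, in this assay, hydrogen in place of formyl on an aromatic carbon gives an at least 14-fold higher number from compound 1 to compound 3 (1.17 log units; beyond the scatter). The value of compound 3 in this pair is a limit of the assay and not a number. The swap of 3-chlorophenyl for 4-bromophenyl on the aromatic nitrogen cannot be read, because the values of compound 2 and compound 3 are both limits: the limit of > 100000 nM in this assay, at which 2 of the 3 values shown sit.

The compounds shown leave open whether formyl would go with a similar step when 3-chlorophenyl sits on the aromatic nitrogen. They also leave open how a nitrile or a carboxylic acid would compare with formyl on that aromatic carbon.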